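Three Limits and an Expected Fourth

The source may report more compounds than this note shows. Statements on the series, on what has been measured and on what is new or still open speak of the compounds shown alone.

Compound 1 `CN1C(=S)[C@@H](NC(=O)c2nc(Cc3ccccc3)n(CCCO)n2)COc2ccccc21`: in a toxicity assay on HT-29 cells (Homo sapiens) for cytotoxicity (on this read-out lower numbers stand for higher toxicity in this test and higher numbers for lower toxicity in this test), compound 1 gives > 100000 nM, a limit of the assay.
Compound 2 `CN1C(=S)[C@@H](NC(=O)c2nc(Cc3ccccc3)n(C3CCCCCC3)n2)COc2ccccc21`: in this assay compound 2 gives > 100000 nM, again only a limit.
Compound 3 `CN1C(=S)[C@@H](NC(=O)c2nc(Cc3ccccc3)n(CC3CCOC3)n2)COc2ccccc21`: in this assay compound 3 gives > 100000 nM, again only a limit.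

Compound 1 therefore stands nowhere as a number, and the two further values shown are limits as well. Because all three sit at the limit of > 100000 nM in this assay, at which 3 of the 3 values shown sit, the steps a step that the two limits leave unreadable from compound 1 to compound 2 and a step that the two limits leave unreadable from compound 1 to compound 3 have no readable size. Compound 4 `CN1C(=S)[C@@H](NC(=O)c2nc(Cc3ccccc3)n(Cc3ccccc3)n2)COc2ccccc21` differs from compound 1 by phenyl in place of 2-hydroxyethyl on a saturated chain carbon bound to an aromatic nitrogen. For the measured compounds named here, no measured step bears a readable size on this change, so no step beyond the scatter is expected in this assay; the estimated step is a step that the limit leaves unreadable from compound 1 to compound 4. Compound 4 is expected at 150000 nM, between 60000 nM and 400000 nM, most probably again reported only as a limit.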

Compound 4, half-maximal cytotoxic concentration: > 100000 nM
Compound 4: a limit, no number (the forecaster's own chance of this, stated with the estimate: 85%); the middle value does not contradict the limit.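

Compound 4 is again only a limit, so its steps to compound 1, compound 2 and compound 3 cannot be read: the limit of > 100000 nM in this assay, at which 4 of the 4 values shown sit.

The compounds shown leave open whether any of these groups on the aromatic nitrogen changes the result in this assay at all.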